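This account rests on a few compounds, and the source may have more. Where it says the series, first, only, none or still open, it means among the compounds named here.

Three close relatives of one shared core have been measured in a functional assay for inhibition, with Homo sapiens as the target; on this read-out lower numbers stand for stronger inhibition and higher numbers for weaker inhibition. Compound 1 `Cc1cccc(Nc2nccc(-c3cccs3)n2)c1` carries a thiophen-2-yl group and gives 300 nM. Compound 2 `Cc1cccc(Nc2nccc(-c3ccc(C)o3)n2)c1` carries a 5-methylfuran-2-yl group in its place; compound 2 gives 2000 nM. Compound 3 `Cc1cccc(Nc2nccc(-c3ccncc3)n2)c1` carries a pyridin-4-yl group, and compound 3 gives 8800 nM, the highest of the three numbers and therefore the weakest inhibition shown so far, separated from the others by a 29-fold higher number from compound 1 to compound 3 (1.47 log units; beyond the scatter) and a 4.4-fold higher number from compound 2 to compound 3 (0.64 log units; beyond the scatter).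

Compound 4 `Cc1cccc(Nc2nccc(-c3ccc(C)s3)n2)c1` is not yet measured. Relative to compound 3 the change is 5-methylthiophen-2-yl in place of pyridin-4-yl on an aromatic carbon. Within the data shown here, two measured steps bear on it. Going from a five-membered ring with one hetero atom to the pyridin-4-yl group cost a 29-fold higher number from compound 1 to compound 3 (1.47 log units; beyond the scatter) and a 4.4-fold higher number from compound 2 to compound 3 (0.64 log units; beyond the scatter); reversing that direction should recover much of the lost inhibition. Between the two five-membered rings themselves, a 6.7-fold higher number from compound 1 to compound 2 (0.82 log units; beyond the scatter) shows that the furan with its methyl sits well above the bare thiophene, so the 5-methylthiophen-2-yl group of compound 4 is expected to land somewhere between those two. The step from compound 3 is therefore expected to be a clearly lower number, a 15-fold lower number from compound 3 to compound 4 (1.17 log units; beyond the scatter). For compound 4 the estimate in this assay is 600 nM, with a likely range from 150 nM to 3000 nM.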

Compound 4, half-maximal inhibitory concentration: 1400 nM
Compound 4: the middle estimate sits 2.3-fold (0.37 log units) below what was measured, and the stated range covers the measured number.
By their numbers in this assay, from the lowest: compound 1; then compounds 4 and 2 (each within the scatter of the next); then compound 3.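

In this assay, the new result separates two changes that were combined in the earlier move from the thiophen-2-yl group to the 5-methylfuran-2-yl group, where the ring and the methyl changed together. Adding only a methyl to the thiophene gives a 4.7-fold higher number from compound 1 to compound 4 (0.67 log units; beyond the scatter), a step large enough to read, whereas replacing the ring oxygen of the furan with sulfur while keeping the methyl gives a 1.4-fold lower number from compound 2 to compound 4 (0.15 log units; within the scatter), so that exchange shows no readable difference among these compounds. Replacing the pyridin-4-yl group with the 5-methylthiophen-2-yl group gives a 6.3-fold lower number from compound 3 to compound 4 (0.80 log units; beyond the scatter), which shows that the two groups differ in this assay even though they have the same counts of heavy atoms, hydrogen-bond donors and hydrogen-bond acceptors.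

No available evidence accounts for any of these differences. Still open, on these data alone, is whether a bare furan-2-yl group would fall close to the thiophen-2-yl group of compound 1, and how an amine, a carboxylic acid or a longer chain would fare in place of the methyl of the 5-methylthiophen-2-yl group.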